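The source may hold more compounds than are shown below. What is called first, only, known or untested is meant among the compounds shown, and "the series" means these compounds.

Measured in a functional assay on HL-60 cells (Homo sapiens) for antiproliferative activity, with a stated time of 72 h; a higher number here means a weaker inhibitor, a lower number a stronger inhibitor:
- compound 1 `OC[C@H]1O[C@@H](n2cnc3c(NCc4cccc(F)c4)ncnc32)[C@H](O)[C@@H]1O` gives 920 nM
- compound 2 `OC[C@H]1O[C@@H](n2cnc3c(NCc4ccc(Cl)cc4)ncnc32)[C@H](O)[C@@H]1O` gives 1700 nM
- compound 3 `OC[C@H]1O[C@@H](n2cnc3c(NCc4ccc(F)c(F)c4F)ncnc32)[C@H](O)[C@@H]1O` gives 13000 nM

Compound 3 has the highest number of the three. Next is compound 4 `OC[C@H]1O[C@@H](n2cnc3c(NCc4c(F)ccc(F)c4F)ncnc32)[C@H](O)[C@@H]1O`, with 2,3,6-trifluorophenyl in place of 2,3,4-trifluorophenyl on a saturated chain carbon bound to a nitrogen on an aromatic ring. Among the compounds with values here, no measured step swaps one trifluorophenyl for another. The closest guides are the large 14-fold higher number from compound 1 to compound 3 (1.15 log units; beyond the scatter) and the modest 7.6-fold higher number from compound 2 to compound 3 (0.88 log units; beyond the scatter), while a 1.8-fold higher number from compound 1 to compound 2 (0.27 log units; within the scatter) shows little sensitivity between the two single-halogen compounds. Compound 3 is the only trifluorophenyl measured, so a modest fall is expected, with no firm direction. The estimated step in this assay is a 2.2-fold lower number from compound 3 to compound 4 (0.34 log units; beyond the scatter). For compound 4 the estimate is 6000 nM, with an expected range of 1500 nM to 20000 nM.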

Compound 4, half-maximal inhibitory concentration: 13000 nM
The estimate for compound 4 lay 2.2-fold (0.34 log units) below the measured number; the range from low to high includes it.
By their numbers in this assay, from the lowest: compounds 1 and 2 (each within the scatter of the next); then compounds 3 and 4 (each within the scatter of the next).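

In this assay, shifting the fluorines from 2,3,4-trifluorophenyl to 2,3,6-trifluorophenyl leaves the number unmoved (no change at the digits printed from compound 3 to compound 4 (within the scatter)), so at this place the two trifluorophenyl compounds read alike. Both stand apart from the single-halogen compounds (a 7.6-fold higher number from compound 2 to compound 4 (0.88 log units; beyond the scatter); a 14-fold higher number from compound 1 to compound 4 (1.15 log units; beyond the scatter)), which shows that the high number of compound 3 is not unique to one trifluorophenyl arrangement. Nothing available explains this shared loss.

Still open, going by these compounds, is whether the rise follows the number of fluorines, which a difluorophenyl would test. Also open, on these data alone, is how a methoxyphenyl or a longer chain would compare with compound 1.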